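The source may report more compounds than this note shows. Statements on the series, on what has been measured and on what is new or still open speak of the compounds shown alone.

Measured so far in a functional assay on A549 cells (Homo sapiens) for inhibition, read by MTT assay, with a stated time of 72 h; on this read-out lower numbers stand for stronger inhibition and higher numbers for weaker inhibition:

compound 1, `O=C(CCC(=O)OCCCCCCSc1ccc([N+](=O)[O-])c2nonc12)Nc1ccccc1F`: 2440 nM
compound 2, `O=C(CCC(=O)OCCCCCCSc1ccc([N+](=O)[O-])c2nonc12)Nc1ccccc1Cl`: 2750 nM

Within the data shown here, compound 2, `O=C(CCC(=O)OCCCCCCSc1ccc([N+](=O)[O-])c2nonc12)Nc1ccccc1Cl`, stands at the higher of the two numbers in this assay, with compound 1, `O=C(CCC(=O)OCCCCCCSc1ccc([N+](=O)[O-])c2nonc12)Nc1ccccc1F`, nearest; the single measured step, a 1.1-fold higher number from compound 1 to compound 2 (0.05 log units; within the scatter), is within the scatter, so the two compounds cannot be separated on these data. Compound 1 gives 2440 nM and compound 2 gives 2750 nM in this assay.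

Compound 3, `Cc1ccccc1NC(=O)CCC(=O)OCCCCCCSc1ccc([N+](=O)[O-])c2nonc12`, differs from compound 2 by one change: methyl in place of chloro on an aromatic carbon. Among the measured compounds shown here, the only measured step that bears on this exchange is the one from compound 1 to compound 2, which also swaps one small substituent for another at the same aromatic carbon ortho to a large group, and it stayed within the scatter. A further exchange of the same kind at that position therefore gives no ground to expect a step beyond the scatter in this assay, in either direction.

Compound 3 is accordingly expected to give about 2600 nM in this assay, with a range of 1300 nM to 5500 nM. The expected step of a 1.1-fold lower number from compound 2 to compound 3 (0.02 log units; within the scatter) is estimated to lie within the scatter.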

Compound 3, half-maximal inhibitory concentration: 4200 nM
Compound 3: middle estimate off by 1.6-fold (0.21 log units), on the low side; measured number inside the range.
By their numbers in this assay, from the lowest: compounds 1, 2 and 3 (each within the scatter of the next).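

In this assay, among these compounds, the first group at this aromatic carbon, ortho to a large group, that is not a halogen gives a 1.5-fold higher number from compound 2 to compound 3 (0.18 log units; within the scatter). Against the fluoro analogue, the same methyl group gives a 1.7-fold higher number from compound 1 to compound 3 (0.24 log units; within the scatter). Fluoro, chloro and methyl at this position therefore leave all three compounds within the scatter of one another, so the series shows no step beyond the scatter for these exchanges, and the order of their numbers carries no weight on these data. Nothing available on these compounds offers an explanation for these numbers.

Still open, on these data alone, is whether a different kind of group at this carbon, such as methoxy, an amine or a carboxylic acid, or plain hydrogen, would give a step beyond the scatter. Also open, as far as these compounds go, is whether fluoro, chloro and methyl would stay as close together at other carbons of the same ring, or on a compound with a longer chain linking the amide end to the shared core.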